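A few compounds are considered here, and "the series" means these few. Any claim that something is new, unique, unknown or untested is made for them only; others in the source may bear on it.

Measured compounds in the series:

compound 1 `O=C1O[C@@H](Cn2ccnn2)CN1c1ccc(-n2cc(-c3ccccn3)cn2)c(F)c1` — a physicochemical assay for lipophilicity, read by HPLC, measured as octanol-water partition (a higher number here means a more lipophilic compound, a lower number a more polar compound), 2
compound 2 `COC(=O)NC[C@H]1CN(c2ccc(-n3cc(-c4ccccn4)cn3)c(F)c2)C(=O)O1` — 2.03

Among the measured compounds shown here, compound 2 holds the higher of the two numbers so far in this assay, but its nearest neighbour, compound 1, lies within the scatter, so the two are not distinguished on these numbers. For the measured compounds named here, the one measured step, a number 0.03 log units higher from compound 1 to compound 2 (within the scatter), concerns the group on the saturated chain carbon bound to the saturated ring carbon and did not move the read-out beyond the scatter.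

Compound 3 `CCNC(=O)NC[C@H]1CN(c2ccc(-n3cc(-c4ccccn4)cn3)c(F)c2)C(=O)O1` is the next compound to be measured in this assay. It differs from compound 2 by ethylamino in place of methoxy on a carbonyl carbon. Going by the values given here, no measured step touches the carbonyl carbon or exchanges the methoxy for an amino group, so the only measured step bears on it indirectly, as a sign that changes in this part of compound 2 have so far stayed within the scatter. A modest downward shift, or none beyond the scatter, is expected, with the step of a number 0.18 log units lower from compound 2 to compound 3 (within the scatter). Compound 3 is therefore estimated at 1.85, in the range 1.45 to 2.25.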

Compound 3, partition coefficient: 2.45
The estimate for compound 3 lay 0.60 log units below the measured number, outside the stated range (above it).
By their numbers in this assay, from the lowest: compounds 1 and 2 (each within the scatter of the next); then compound 3.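

In this assay, among the compounds shown here, the carbonyl carbon carrying the methoxy of compound 2 proves to be a place where the read-out responds: ethylamino in place of methoxy gives a number 0.42 log units higher from compound 2 to compound 3 (beyond the scatter), the first step to pass the scatter. Set against compound 1, the group on the saturated chain carbon now matters as well, with (ethylcarbamoyl)amino in place of 1H-1,2,3-triazol-1-yl giving a number 0.45 log units higher from compound 1 to compound 3 (beyond the scatter), whereas (methoxycarbonyl)amino at that same place left the number within the scatter, so the outcome there depends on which group enters and not merely on the triazolyl group leaving. Nothing available accounts for the rise.

The compounds shown do not separate the contribution of the nitrogen from that of the ethyl chain in the entering ethylamino group. Amino, methylamino or a longer chain such as propylamino on the same carbonyl carbon would show whether the number follows the length of the chain or stays put once any amino group replaces methoxy.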